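A few compounds are considered here, and "the series" means these few. Any claim that something is new, unique, unknown or untested is made for them only; others in the source may bear on it.

In a functional assay on A-375 cells (Homo sapiens) for activation, with a stated time of 3 days (a higher number here means that more compound is needed for the effect, a lower number that less compound is needed), compound 1 `O=C(Nc1ccc(-c2cscn2)cc1)C1CCCN(Cc2cccc(F)c2)C1` gives 5000 nM and compound 2 `O=C(Nc1ccc(-c2ccncc2)cc1)C1CCCN(Cc2ccc(F)c(F)c2)C1` gives 1180 nM as the lower of the two numbers, a gap beyond the scatter. Compound 3 `O=C(Nc1ccc(-c2ccoc2)cc1)C1CCCN(Cc2ccc(F)c(F)c2)C1` differs from compound 2 by furan-3-yl in place of pyridin-4-yl on an aromatic carbon with furan-3-yl in place of pyridin-4-yl on an aromatic carbon. Among the compounds with values here, no measured pair shows this change alone, so a modest rise just beyond the scatter in this assay is expected only tentatively, resting on compound 1 at 5000 nM as the sole higher number. The estimated step is a 2.1-fold higher number from compound 2 to compound 3 (0.33 log units; beyond the scatter) as an expectation only. For compound 3 the expected value is 2500 nM with an estimated range from 800 nM to 7000 nM for this read-out.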

Compound 3, half-maximal effective concentration: 3000 nM
The estimate for compound 3 lay 1.2-fold (0.08 log units) below the measured number; the range from low to high includes it.
By their numbers in this assay, from the lowest: compound 2; then compounds 3 and 1 (each within the scatter of the next).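

In this assay, within the data shown here, the replacement of pyridin-4-yl by furan-3-yl, on an aromatic carbon para to a large group, gives a 2.5-fold higher number from compound 2 to compound 3 (0.41 log units; beyond the scatter), the first reading of a single change at this place. The two rings carry the same counts of hydrogen-bond donors and acceptors, so the step shows that this place responds to an exchange that leaves those counts unchanged. Nothing measured here accounts for the step. As far as these compounds go, whether an amine or a carboxylic acid on this ring would lower the number remains open, as does whether the step holds with other groups elsewhere on the shared core.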